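A few compounds are considered here, and "the series" means these few. Any claim that something is new, unique, unknown or untested is made for them only; others in the source may bear on it.

The two measured compounds share one core and differ only in the group on an oxygen on a saturated carbon. Compound 1, `COc1nc(C)c(Nc2nc(Cl)cn([C@H](COC(=O)Nc3cccnc3)C3CC3)c2=O)cc1C`, gives 10 nM in an assay on frontal cortex for displacement of a labelled ligand from corticotropin-releasing factor receptor 1 (Rattus norvegicus), with a stated time of 2 h; a higher number here means a weaker inhibitor, a lower number a stronger inhibitor. Compound 2, `COc1nc(C)c(Nc2nc(Cl)cn([C@H](COc3cc(Br)ccn3)C3CC3)c2=O)cc1C`, gives 1.5 nM in this assay. Among the measured compounds shown here, of these two numbers, that of compound 1 is the higher; its only neighbour is compound 2, and the single measured step reads a 6.7-fold lower number from compound 1 to compound 2 (0.82 log units; beyond the scatter).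

Compound 3, `Cc1cc(Nc2nc(Cl)cn([C@H](COC(=O)Nc3cccnc3)C3CC3)c2=O)c(C)nc1OC(F)F`, has not yet been measured in this assay. It departs from compound 1 at another place: difluoromethyl in place of methyl on an oxygen on an aromatic ring, so that 6-methoxy-2,5-dimethylpyridin-3-yl becomes 6-(difluoromethoxy)-2,5-dimethylpyridin-3-yl. For the measured compounds named here, the one measured step concerns the exchange of (pyridin-3-yl)carbamoyl for 4-bromopyridin-2-yl on the other side of the core and says nothing about the oxygen on the aromatic ring. Going by the values given here, no measured step therefore bears on the change from compound 1 to compound 3, and no shift beyond the usual scatter is expected in this assay. Compound 3 is estimated to give about 10 nM in this assay, most likely between 4 nM and 25 nM. The expected step is no change at the digits printed from compound 1 to compound 3 (within the scatter), an estimate with no clear direction.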

Compound 3, half-maximal inhibitory concentration: 1.9 nM
Estimate against measurement, compound 3: 5.3-fold (0.72 log units) above; measured number below the stated range.
By their numbers in this assay, from the lowest: compounds 2 and 3 (each within the scatter of the next); then compound 1.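

Difluoromethyl in place of methyl on an oxygen on an aromatic ring gives a 5.3-fold lower number from compound 1 to compound 3 (0.72 log units; beyond the scatter) in this assay, so this part of the molecule, on which the earlier compounds were silent, also affects the number. Until now, only the group on an oxygen on a saturated carbon had been seen to do so, with a 6.7-fold lower number from compound 1 to compound 2 (0.82 log units; beyond the scatter); the new step shows that a lower number can also be reached with the (pyridin-3-yl)carbamoyl group left as it stands in compound 1. Nothing available here accounts for the size or direction of the new step.

The compounds shown leave open whether the two changes add up, since difluoromethoxy and the 4-bromopyridin-2-yl group do not appear together in any one of them. They also leave open how far the trend runs on this oxygen, as only methyl and difluoromethyl are shown there, so that an ethyl or trifluoromethyl group on the oxygen, or an amine in place of the methoxy group, remains an open case.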